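Methoxy for acetoxy in a cyclopentenedione cytotoxicity series

The source may report more compounds than this note shows. Statements on the series, on what has been measured and on what is new or still open speak of the compounds shown alone.

Of the compounds shown here, two of a shared core have been measured in an ADME assay on LLC-PK1 cells (Sus scrofa) for cytotoxicity, read by neutral red uptake; a higher number here means a weaker inhibitor, a lower number a stronger inhibitor. Compound 1 `COC(/C=C/c1ccc(O)cc1)=C1\C(=O)C=C(C)C1=O` gives 3.4 ug/mL. Compound 2 `CC(=O)OC(/C=C/c1ccccc1)=C1\C(=O)C=C(C)C1=O` gives 4.9 ug/mL. Compound 2 stands at the upper end of these two numbers, and its gap to compound 1 lies within the usual scatter, so the two results cannot be told apart. For the measured compounds named here, the two compounds also differ in more than one place, so no single step between them can be read off.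

Compound 3 `COC(/C=C/c1ccccc1)=C1\C(=O)C=C(C)C1=O` has not yet been measured in this assay. It differs from compound 2 in one place: methyl in place of acetyl on an oxygen on an unsaturated carbon. Going by the values given here, the oxygen substituent that enters is the one compound 1 carries, so compound 3 shares that feature with compound 1 while keeping the rest of compound 2.

Among the compounds with values here, with only two measurements, both within scatter of each other, the account expects the step of a 1.2-fold lower number from compound 2 to compound 3 (0.09 log units; within the scatter) to stay inside the scatter, in no firm direction. On that basis compound 3 is estimated at 4 ug/mL, with a range from 2 ug/mL to 8 ug/mL.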

Compound 3, half-maximal inhibitory concentration: 3.4 ug/mL
The estimate for compound 3 lay 1.2-fold (0.07 log units) above the measured number; the measured number falls inside the stated range.
By their numbers in this assay, from the lowest: compounds 1, 3 and 2 (each within the scatter of the next).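

In this assay, methyl in place of acetyl on the oxygen gives a 1.4-fold lower number from compound 2 to compound 3 (0.16 log units; within the scatter) and so stays inside the scatter: on this oxygen on an unsaturated carbon, going from acetoxy to methoxy produces no difference that these data can resolve. Compound 3 also supplies the single-place link that compound 1 and compound 2 lacked, and hydrogen in place of hydroxy on an aromatic carbon gives no change at the digits printed from compound 1 to compound 3 (within the scatter) so that this second change likewise cannot be told from the scatter. Nothing in the material shown speaks to why either step is as small as it is.

The compounds shown cover only methyl and acetyl on that oxygen and only hydrogen and hydroxy on the aromatic carbon, so neither position has yet given a step that can be read beyond the scatter. On these data alone, whether a longer chain such as butyl on the oxygen, or an amine on the aromatic carbon, would move the number clearly in this assay remains open.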